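The compounds below may be only part of what the source reports. "The series", "measured", "known", "first", "only" and "open" are said of these compounds alone.

In a functional assay on MDA-MB-231 cells (Homo sapiens) for antiproliferative activity, read by MTT assay, with a stated time of 24 h (a higher number here means a weaker inhibitor, a lower number a stronger inhibitor), compound 1, `O=C1O/C(=C\Cn2cc(C3=CCCCC3)nn2)C(OCc2ccccc2)=C1OCc1ccccc1`, reaches only the limit of the measurement, > 100000 nM, so no number is known for it. Compound 3, `CCCc1cn(CCC2(O)C(OCc3ccccc3)=C(OCc3ccccc3)C(=O)N2CCC)nn1`, likewise returns only a limit, > 100000 nM. Among the measured compounds shown here, compound 2, `O=C1NC(O)(CCn2cc(C3=CCCCC3)nn2)C(OCc2ccccc2)=C1OCc1ccccc1`, is the one compound of the three that gives a number, 13100 nM, so compound 1 stands at the limit of > 100000 nM in this assay, at which 2 of the 3 values shown sit, rather than at any measured potency. Compound 4, `CC(C)(C)c1ccc(-c2cn(C/C=C3\OC(=O)C(OCc4ccccc4)=C3OCc3ccccc3)nn2)cc1`, carries 4-(tert-butyl)phenyl in place of cyclohex-1-en-1-yl on an aromatic carbon on the shared core of compound 1. For the measured compounds named here, with no step between measured compounds to lean on, any change expected in this assay from this replacement rests on compound 1 alone and is uncertain in size, though a gain beyond the scatter is possible. Compound 4 is estimated at 80000 nM, between 15000 nM and 300000 nM, an expected step of an at least 1.2-fold lower number from compound 1 to compound 4 (0.09 log units; that floor lies within the scatter).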

Compound 4, half-maximal inhibitory concentration: 51200 nM
Beside the measured number, compound 4's estimate is 1.6-fold (0.19 log units) above it; the measured number falls inside the stated range.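

On the shared core, the aromatic carbon of the five-membered aromatic ring with 3 nitrogen takes 4-(tert-butyl)phenyl in place of cyclohex-1-en-1-yl, and in this assay compound 4 now gives a measured number, 51200 nM. The change amounts to an at least 1.9-fold lower number from compound 1 to compound 4 (0.29 log units; that floor lies within the scatter). Going by these compounds, its true size stays unknown because compound 1 is held at a limit: the limit of > 100000 nM in this assay, at which 2 of the 4 values shown sit. The compounds shown leave open how an amine, a carboxylic acid or a longer chain at this aromatic carbon would read in this assay.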